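A few compounds are considered here, and "the series" means these few. Any claim that something is new, unique, unknown or untested is made for them only; others in the source may bear on it.

Values in an ADME assay on BaF3 cells (Mus musculus) for cytotoxicity, read by CellTiter-Glo and CCK-8 assay, with a stated time of 72 h (on this read-out higher numbers stand for weaker inhibition of growth and lower numbers for stronger inhibition of growth), each one a limit:
- compound 1 `Cc1ccc(NC(=O)c2ccc(CNCCN(C)C)cc2)cc1Nc1nccc(-c2cccnc2)n1` gives > 10000 nM
- compound 2 `C=CC(=O)N(CCN(C)C)Cc1ccc(C(=O)Nc2ccc(C)c(Nc3nccc(-c4cccnc4)n3)c2)cc1` gives > 10000 nM
- compound 3 `Cc1ccc(NC(=O)c2ccc(CN(CCN(C)C)C(=O)C(C)C)cc2)cc1Nc1nccc(-c2cccnc2)n1` gives > 10000 nM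

Compound 3 stands at > 10000 nM, which is a limit and not a number. The whole set sits in the same place: the limit of > 10000 nM in this assay, at which 3 of the 3 values shown sit. Compound 4 `Cc1ccc(NC(=O)c2ccc(CN(CCN(C)C)C(=O)C(C)(C)C)cc2)cc1Nc1nccc(-c2cccnc2)n1` differs from compound 3 by methyl in place of hydrogen on a saturated chain carbon bound to a carbonyl carbon and two saturated chain carbons, that is, isopropylcarbonyl goes to (tert-butyl)carbonyl. Closest in kind is a step that the two limits leave unreadable from compound 2 to compound 3, and a step that the two limits leave unreadable from compound 1 to compound 2 and a step that the two limits leave unreadable from compound 1 to compound 3 also bear on it. None of these has a readable size, so no direction can be drawn from them, and no step beyond the scatter is expected in this assay. The estimate is a step that the limit leaves unreadable from compound 3 to compound 4. For compound 4 the expected value is 15000 nM, within an estimated range from 8000 nM to 30000 nM, most likely reported again as a limit.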

Compound 4, concentration for 50% growth inhibition: > 10000 nM
Compound 4 was reported as a limit; the forecaster's own chance of this, stated with the estimate: 90%; the middle value does not contradict the limit.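

The steps from compound 1, compound 2 and compound 3 to compound 4 in this assay cannot be read, as every value is a limit: the limit of > 10000 nM in this assay, at which 4 of the 4 values shown sit.

The compounds shown leave open whether any group on this amine nitrogen gives a readable growth-inhibition value.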